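The source may hold more compounds than are shown below. What is called first, only, known or untested is meant among the compounds shown, and "the series" means these compounds.

Working notes on the series.

Of the compounds shown here, three have been measured. Compound 1 `CCC[C@H](C)n1c(CC)nc2c(-c3ccc(OC(F)(F)F)cc3Cl)nccc21` gives 2.3 nM in an assay for binding affinity to Corticotropin releasing factor receptor (Rattus norvegicus); a higher number here means a weaker inhibitor, a lower number a stronger inhibitor. Compound 2 `CCC[C@@H](C)n1c(CC)nc2c(-c3ccc(OC(F)(F)F)cc3Cl)nccc21` gives 1.9 nM in this assay. Compound 3 `CCCC(C)n1c(CC)nc2c(-c3ccc(OC(F)(F)F)cc3Cl)nccc21` gives 2.8 nM in this assay. The steps of a 1.2-fold lower number from compound 1 to compound 2 (0.08 log units; within the scatter), a 1.2-fold higher number from compound 1 to compound 3 (0.09 log units; within the scatter) and a 1.5-fold higher number from compound 2 to compound 3 (0.17 log units; within the scatter) all lie within the scatter, so compound 3 stands level with the other two; the differences between these three rest only on (the fact that compounds 1 and 2 differ only in the configuration as drawn), the fact that one of compounds 1 and 3 is drawn with a defined configuration and the other without, at the place where they differ and (the fact that one of compounds 2 and 3 is drawn with a defined configuration and the other without, at the place where they differ).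

The next compound is compound 4 `CCCC(C)n1c(CC)nc2c(-c3ccc(C(F)(F)F)cc3Cl)nccc21`. It differs from compound 3 by trifluoromethyl in place of trifluoromethoxy on an aromatic carbon. Within the data shown here, none of the measured steps touches this part of the molecule: all three concern only the configuration at the saturated chain carbon and leave the aromatic substituent untouched. Among the measured compounds shown here, there is thus no measured step in this assay on which to size this change, and the shared core with its chain is carried over unchanged. The expectation is therefore a step of a 1.1-fold higher number from compound 3 to compound 4 (0.03 log units; within the scatter), that is, no change beyond the scatter, with wide uncertainty. Compound 4 is estimated at 3 nM, in the range 1 nM to 10 nM.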

Compound 4, inhibition constant: 3.5 nM
For compound 4 the middle estimate is 1.2-fold (0.07 log units) below the measured one; measured number inside the range.
By their numbers in this assay, from the lowest: compounds 2, 1, 3 and 4 (each within the scatter of the next).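

In this assay, trifluoromethyl in place of trifluoromethoxy on this aromatic carbon, meta to a chloro group, gives a 1.3-fold higher number from compound 3 to compound 4 (0.10 log units; within the scatter), so the two groups stand level at this position and losing the oxygen of trifluoromethoxy has no effect beyond the scatter. Among these compounds, this is the first measured step at the aromatic substituent, as the earlier steps concerned only the saturated chain carbon. Nothing on hand bears on the reason for this result.

The compounds shown leave open whether this position also accepts a group without fluorine, such as an amine, a carboxylic acid or methoxy. Among the compounds shown here, they also leave open whether the step keeps its size with the single configurations drawn for compound 1 and compound 2, since compound 3 and compound 4 are both drawn without a configuration at the chain carbon.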